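Swapping the aryl group on the pyrazole core

The source may hold more compounds than are shown below. What is called first, only, known or untested is meant among the compounds shown, and "the series" means these compounds.

Measured so far:
compound 1, `Cc1cc(-c2c(C)nn(-c3nc(-c4ccc(Cl)c(Cl)c4)c(SC(C)C)s3)c2C(=O)O)cc(C)n1`, 580 nM in a functional assay on BJAB cells (Homo sapiens) for antiproliferative activity, with a stated time of 4 days; a lower number here means that less compound is needed, a higher number that more compound is needed for the effect
compound 2, `Cc1nn(-c2nc(-c3ccc(Cl)c(Cl)c3)c(SC(C)C)s2)c(C(=O)O)c1-c1ccccc1Cl`, 13100 nM in this assay

Compound 2 gives the highest of the two numbers in this assay; its nearest neighbour is compound 1, and the step of a 23-fold higher number from compound 1 to compound 2 (1.35 log units; beyond the scatter) came from exchanging one aryl group. Compound 3, `Cc1nn(-c2nc(-c3ccc(Cl)c(Cl)c3)c(SC(C)C)s2)c(C(=O)O)c1-c1ccc(C(F)(F)F)cc1`, carries the change (4-(trifluoromethyl)phenyl in place of 2-chlorophenyl on an aromatic carbon). Among the compounds with values here, no measured step compares two phenyl groups directly, so the only guide is that this position is sensitive. For compound 3 the expected step is a 1.3-fold lower number from compound 2 to compound 3 (0.12 log units; within the scatter), and compound 3 is estimated at 10000 nM, between 3000 nM and 40000 nM.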

Compound 3, half-maximal effective concentration: 3500 nM
Compound 3: middle estimate off by 2.9-fold (0.46 log units), on the high side; measured number inside the range.
By their numbers in this assay, from the lowest: compound 1; then compound 3; then compound 2.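

In this assay the result shows that this position tolerates more than one phenyl group to different degrees: 4-(trifluoromethyl)phenyl gives a 3.7-fold lower number from compound 2 to compound 3 (0.57 log units; beyond the scatter) and so stands clear of 2-chlorophenyl. It still does not match 2,6-dimethylpyridin-4-yl, with a 6.0-fold higher number from compound 1 to compound 3 (0.78 log units; beyond the scatter) for the exchange of that ring. Nothing available explains these differences.

From the compounds shown here alone, the two phenyl groups differ in both the substituent and its place on the ring, so their separate contributions stay open. Plain phenyl or 4-chlorophenyl would help to separate them.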